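The source may hold more compounds than are shown below. What is called first, only, known or untested is meant among the compounds shown, and "the series" means these compounds.

Within the data shown here, compound 2 `O=C(CSc1nnc(-c2ccncc2)n1-c1ccccc1)N/N=C/c1ccc(Br)cc1` gives the lower of the two numbers so far: in a functional assay on MCF7 cells (Homo sapiens) for inhibition, read by MTT assay, with a stated time of 48 h (a lower number here means a stronger inhibitor, a higher number a weaker inhibitor), compound 2 gives 7040 nM, while compound 1 `O=C(CSc1nnc(-c2ccncc2)n1-c1ccccc1)N/N=C/c1ccccc1` gives 23600 nM. Compound 3 `O=C(CSc1nnc(-c2ccncc2)n1-c1ccccc1)N/N=C/c1ccccc1F` carries the change (2-fluorophenyl in place of 4-bromophenyl on a carbon with a double bond to nitrogen). Among the measured compounds shown here, the only measured step, a 3.4-fold lower number from compound 1 to compound 2 (0.53 log units; beyond the scatter), concerns bromo in place of hydrogen and does not cover a fluorine placed differently, so it bears only loosely on this change. Compound 3 is therefore expected to land between the two measured values, with an estimated step of a 2.1-fold higher number from compound 2 to compound 3 (0.33 log units; beyond the scatter). The estimate for compound 3 is 15000 nM, within 6000 nM to 40000 nM.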

Compound 3, half-maximal inhibitory concentration: 22400 nM
Estimate against measurement, compound 3: 1.5-fold (0.17 log units) below; the measured number falls inside the stated range.
By their numbers in this assay, from the lowest: compound 2; then compounds 3 and 1 (each within the scatter of the next).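

Within this assay, 2-fluorophenyl in place of 4-bromophenyl gives a 3.2-fold higher number from compound 2 to compound 3 (0.50 log units; beyond the scatter) and so does not keep the lower number of compound 2. Fluoro in place of hydrogen gives a 1.1-fold lower number from compound 1 to compound 3 (0.02 log units; within the scatter) and leaves compound 3 level with compound 1, so a halogen on this aromatic ring does not by itself lower the number, and compound 3 goes against any such pattern. No measured evidence accounts for this result. Because this change alters both the halogen and its place, the compounds shown cannot separate the two. On these data alone, how a methoxy group or an amine on this ring would read also stays open.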